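The compounds below may be only part of what the source reports. "The series", "measured", "known", "first", "only" and "open" are said of these compounds alone.

Of the compounds shown here, two built on the shared core have been measured so far in an in vitro ADME assay on microsomes from liver (Homo sapiens) for metabolic stability; a higher number here means that the compound lasts longer, a lower number that the compound disappears faster. Compound 1 (`CC(=O)c1cc(C(=O)O)c(Nc2ccc(I)cc2F)n1C`) gives 2.05 h as its half-life, and compound 2 (`CC(=O)c1cc(C(=O)N2CC(O)C2)c(Nc2ccc(I)cc2F)n1C`) gives 0.25 h and so stands lowest of the two numbers. Among the measured compounds shown here, the one measured step is an 8.2-fold lower number from compound 1 to compound 2 (0.91 log units; beyond the scatter) and it comes with 3-hydroxyazetidin-1-yl in place of hydroxy on a carbonyl carbon. Compound 3 (`CC(=O)c1cc(C(=O)N2CC(N)C2)c(Nc2ccc(I)cc2F)n1C`) keeps the ring of compound 2 and carries amino in place of hydroxy on a saturated ring carbon is the whole difference. The swap sits on a saturated ring carbon of a four-membered non-aromatic ring with 1 nitrogen. For the measured compounds named here, the measured step lies at another place, so its size does not carry over, and no measured pair covers this swap. With only the value of compound 2 to go on, no step beyond the scatter is expected in this assay here. The estimated step is a 1.2-fold higher number from compound 2 to compound 3 (0.08 log units; within the scatter) and it stays within the scatter. For compound 3 the expected half-life is 0.3 h (estimated range 0.13 h to 0.8 h).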

Compound 3, half-life: 0.917 h
For compound 3 the middle estimate is 3.1-fold (0.49 log units) below the measured one, outside the stated range (above it).
By their numbers in this assay, from the lowest: compound 2; then compound 3; then compound 1.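

In this assay, amino in place of hydroxy on a saturated ring carbon, two ring bonds from the ring nitrogen, gives a 3.7-fold higher number from compound 2 to compound 3 (0.56 log units; beyond the scatter) and so shows that exchanging one heavy atom at this position is enough to move the half-life beyond the scatter, even though hydroxy and amino are counted with the same hydrogen-bond donors and acceptors. Among the compounds shown here, until now, the only change seen was the one on the carbonyl carbon, an 8.2-fold lower number from compound 1 to compound 2 (0.91 log units; beyond the scatter), which could not show whether the substituent on the four-membered ring mattered; it does, yet 3-aminoazetidin-1-yl in place of hydroxy on a carbonyl carbon still gives a 2.2-fold lower number from compound 1 to compound 3 (0.35 log units; beyond the scatter), so the amino group closes only part of the gap to compound 1. Nothing available here accounts for the difference between hydroxy and amino at this position.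

On these data alone, it remains open whether methylamino, dimethylamino or aminomethyl on the same ring carbon would lie nearer compound 2 or compound 3. As far as these compounds go, it is also open whether any group at this position could bring the half-life up to that of compound 1 at 2.05 h in this assay.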